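Trifluoromethoxy for trifluoromethyl on the shared core: clearance notes

This account rests on a few compounds, and the source may have more. Where it says the series, first, only, none or still open, it means among the compounds named here.

Measured so far in an ADME assay on liver for metabolic stability, with Liver microsome (Homo sapiens) as the target, read by LC-MS, using microsomes, with a stated time of 5 h; on this read-out higher numbers stand for fast clearance and lower numbers for slow clearance:
compound 1 `C[C@]1(O)C[C@@](c2cccc(C(F)(F)F)c2)([C@H](O)c2ccccn2)C1` — 150 mL/min/kg
compound 2 `O[C@H](c1ccccn1)C1(c2ccc(OC(F)(F)F)cc2)CCC1` — 333 mL/min/kg

Compound 1 stands lowest of the two numbers in this assay; compound 2, which is built on a different core, gives a higher number in this assay, and the gap between the two lies beyond the usual scatter. Among the measured compounds shown here, no step between measured compounds that differ in one place has been recorded, so the two values can only be set side by side.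

Compound 3 `C[C@]1(O)C[C@@](c2cccc(OC(F)(F)F)c2)([C@H](O)c2ccccn2)C1` is the unmeasured analogue of compound 1 with trifluoromethoxy in place of trifluoromethyl on an aromatic carbon. For the measured compounds named here, no measured pair covers this change on the shared core. Compound 3 is expected to move toward somewhat faster clearance in this assay, a step of a 1.4-fold higher number from compound 1 to compound 3 (0.15 log units; within the scatter) that may not exceed the scatter. Compound 3 is estimated at 210 mL/min/kg, with a range from 110 mL/min/kg to 400 mL/min/kg.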

Compound 3, clearance: 167 mL/min/kg
The estimate for compound 3 lay 1.3-fold (0.10 log units) above the measured number; the measured number falls inside the stated range.
By their numbers in this assay, from the lowest: compounds 1, 3 and 2 (each within the scatter of the next, the first and the last beyond it).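

Among the compounds shown here, on the shared core, the change from trifluoromethyl to trifluoromethoxy on an aromatic carbon, meta to a large group, gives the first single-place step that can be read in this assay (a 1.1-fold higher number from compound 1 to compound 3 (0.05 log units; within the scatter)). At this position, the two groups cannot be told apart on this read-out, even though trifluoromethoxy brings one more heavy atom and a hydrogen-bond acceptor. No measured property of either group bears on this result, so the data offer no explanation for it.

Going by these compounds, it remains open what a nitrile or an amine in the same place would do to clearance. On these data alone, it also remains open whether the same exchange would give a comparable step on the core of compound 2.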